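The compounds below may be only part of what the source reports. "The series", "measured", "known", "first", "only" and "open" are said of these compounds alone.

Measured in a functional assay on L1210 cells (Mus musculus) for inhibition; a lower number here means a stronger inhibitor, a higher number a weaker inhibitor:

- compound 1 `C=Cc1cc(O)nc(O)n1`: 3000 nM
- compound 2 `C=Cc1nc(O)nc(O)c1Br`: 11000 nM

Of these two numbers, the lower belongs to compound 1, at 3000 nM. Compound 3 `C/C=C/c1cc(O)nc(O)n1` has not yet been measured in this assay. It differs from compound 1 in one place: prop-1-en-1-yl in place of vinyl on an aromatic carbon.

Going by the values given here, only one measured step is available, a 3.7-fold higher number from compound 1 to compound 2 (0.56 log units; beyond the scatter), which comes with bromo in place of hydrogen on an aromatic carbon. Among the compounds with values here, it is a different change and bears on this one only indirectly, since no measured pair alters the vinyl group itself. Within the data shown here, it does show that the one addition made to compound 1 so far gave a modest move to a higher number. A step of similar modest size in the same direction is therefore expected, though with wide uncertainty, and a result within the scatter would not be surprising.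

For compound 3 the expected value is 10000 nM, with an estimated range from 3000 nM to 40000 nM. This estimate amounts to an expected 3.3-fold higher number from compound 1 to compound 3 (0.52 log units; beyond the scatter).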

Compound 3, half-maximal inhibitory concentration: > 90000 nM
Compound 3: only a limit was reported; the forecaster's own chance of this, stated with the estimate: 10%; middle value at least 9.0-fold (0.95 log units) from the limit.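

In this assay, going by these compounds alone, the aromatic carbon that carries vinyl proves far less forgiving than the earlier compounds could show: prop-1-en-1-yl in place of vinyl gives an at least 30-fold higher number from compound 1 to compound 3 (1.47 log units; beyond the scatter). Within the data shown here, this is the first change to the vinyl group itself, and it keeps the double bond while going from 2 heavy atoms to 3, yet the step is larger than a 3.7-fold higher number from compound 1 to compound 2 (0.56 log units; beyond the scatter), the only step known before, which involved bromo on another aromatic carbon. Going by these compounds, the value of compound 3 is a limit and not a number, and the full size of the step therefore remains unknown: the limit of > 90000 nM in this assay, at which 1 of the 3 values shown sits.

The compounds shown leave open whether any other group at this carbon, such as a methyl, an ethyl, an amine or a carboxylic acid, could keep the number near that of compound 1. They also give no way of telling why this single change has such a large effect, or whether a longer chain would behave in the same way as prop-1-en-1-yl.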